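Cytotoxicity of a para-substituted benzylamino series

A few compounds are considered here, and "the series" means these few. Any claim that something is new, unique, unknown or untested is made for them only; others in the source may bear on it.

Measured so far in an ADME assay on J774.A1 cells (Mus musculus) for cytotoxicity, read by MTT assay, with a stated time of 48 h; a higher number here means that more compound is tolerated, a lower number that less compound is tolerated

Compound 1 (`COC(=O)c1c(NCc2ccc(F)cc2)noc1-c1ccc([N+](=O)[O-])cc1`) with "not determined" (no result reported)
Compound 2 (`COC(=O)c1c(NCc2ccc(Cl)cc2)noc1-c1ccc([N+](=O)[O-])cc1`) with 78300 nM
Compound 3 (`COC(=O)c1c(NCc2ccc(OC)cc2)noc1-c1ccc([N+](=O)[O-])cc1`) with "not determined" (no result reported)

Compound 3 stands without a single number in this assay and compound 1 is in the same position. Going by the values given here, the only figure is therefore the one for compound 2 at 78300 nM in this read-out.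

Compound 4 (`COC(=O)c1c(NCc2ccc(C(C)(C)C)cc2)noc1-c1ccc([N+](=O)[O-])cc1`) is still to be measured. The structural change tert-butyl in place of methoxy on an aromatic carbon puts tert-butyl in place of methoxy on an aromatic carbon, para to a large group. Among the compounds with values here, no measured pair shows what such a change does, and compound 3 offers no starting value. The step in this assay is expected to stay within the scatter, with no favoured direction, and compound 2 at 78300 nM serves as the sole reference for that expectation. Compound 4 is expected to give 65000 nM with an estimated range from 25000 nM to 150000 nM around it.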

Compound 4, half-maximal cytotoxic concentration: 81400 nM
The estimate for compound 4 lay 1.3-fold (0.10 log units) below the measured number; the range from low to high includes it.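

In this assay the series now has its first readable step at this position: tert-butyl in place of chloro on the aromatic carbon gives a 1.0-fold higher number from compound 2 to compound 4 (0.02 log units; within the scatter). Compound 2 and compound 4 therefore stand level within the scatter, so this exchange of chloro for the larger-counted tert-butyl group has no readable effect on the tolerated concentration, something a single figure could not show. No measured information offers an explanation for this result.

The step from methoxy to tert-butyl cannot be read, as compound 3 has no single number, and so the methoxy compound cannot be placed relative to the other two. From the compounds shown here alone, whether an amine or a carboxylic acid at this place would stand at the same level remains open.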